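The source may hold more compounds than are shown below. What is called first, only, known or untested is meant among the compounds shown, and "the series" means these compounds.

Measured compounds:
compound 1, `c1ccc(CCc2ccc3c(NCCCNCc4ccco4)ccnc3c2)cc1`, 9.47
compound 2, `COc1ccc(F)cc1CNCCCNc1ccnc2cc(CCc3ccccc3)ccc12`, 9.47
compound 3, `COc1cccc(CNCCCNc2ccnc3cc(CCc4ccccc4)ccc23)c1O`, 9.47

These three share a core and differ only in the group on the saturated chain carbon bound to an amine nitrogen. In a physicochemical assay for acid dissociation, compound 1 stands level with compounds 2 and 3, with steps of no change at the digits printed from compound 1 to compound 2 (within the scatter) and no change at the digits printed from compound 1 to compound 3 (within the scatter); between the other two the step is no change at the digits printed from compound 2 to compound 3 (within the scatter).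

Compound 4, `c1coc(CNCCCNc2ccnc3cc(C4CCCCC4)ccc23)c1`, is not yet measured. Against compound 1 the change is cyclohexyl in place of phenethyl on an aromatic carbon. For the measured compounds named here, no measured step alters this aromatic carbon, so none bears on it directly; what the three steps do show is that swapping groups elsewhere on the molecule left this assay unchanged within the scatter. On that basis no step beyond the scatter is expected here either, so compound 4 is expected to give 9.47, between 9.15 and 9.8, a step of no change at the digits printed from compound 1 to compound 4 (within the scatter) that is expected to sit within the scatter.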

Compound 4, acid dissociation constant: 9.47
Compound 4: the middle estimate sits on the measured number at the digits printed; low and high end bracket the measured number.
By their numbers in this assay, from the lowest: compounds 1, 2, 3 and 4 (each within the scatter of the next).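

For the compounds shown here, the earlier compounds differed only in the group on the saturated chain carbon bound to an amine nitrogen, so compound 4 is the first to test an aromatic carbon of the shared core. In this assay, cyclohexyl in place of phenethyl at this carbon gives no change at the digits printed from compound 1 to compound 4 (within the scatter), although the group goes from 8 heavy atoms to 6 and its six-membered ring is no longer aromatic. Nothing available accounts for this result.

On these data alone, both groups at this aromatic carbon contain only carbon and carry no net charge, so the effect of an amine or a carboxylic acid there remains open. Also open, as far as these compounds go, is whether a longer chain in place of the one carrying the amine nitrogen would leave the reading in this assay as it stands.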